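The source may hold more compounds than are shown below. What is called first, only, known or untested is meant among the compounds shown, and "the series" means these compounds.

Compound 1 `O=C(Nc1cccc(-n2cc(-c3ccncc3)c(-c3ccc(Cl)c(O)c3)n2)c1)Nc1ccc(Cl)c(Cl)c1` sits in a functional assay on RXF 393 cells (Homo sapiens) for inhibition, read by sulforhodamine B assay, with a stated time of 48 h (a higher number here means that more compound is tolerated, a lower number that less compound is tolerated), at a limit, > 32500 nM, and no number is known for it. Compound 3 `COc1cc(-c2nn(-c3cccc(NC(=O)c4ccccc4)c3)cc2-c2ccncc2)ccc1Cl` likewise gives only a limit in this assay, > 100000 nM. Compound 2 `COc1cc(-c2nn(-c3cccc(NC(=O)Nc4cccc(C(F)(F)F)c4)c3)cc2-c2ccncc2)ccc1Cl` gives a number in this assay, 4830 nM. Within the data shown here, the one measured step, an at least 20-fold higher number from compound 2 to compound 3 (1.31 log units; beyond the scatter), is a change at the carbonyl and does not match the change to compound 4 `O=C(Nc1cccc(-n2cc(-c3ccncc3)c(-c3ccc(Cl)c(O)c3)n2)c1)Nc1ccc(Cl)c(C(F)(F)F)c1`, which is trifluoromethyl in place of chloro on an aromatic carbon. Compound 2 does share the entering trifluoromethyl group with compound 4, so a number rather than a limit is possible. Compound 4 is expected to give 20000 nM in this assay, between 5000 nM and 100000 nM. That estimate means a step of an at least 1.6-fold lower number from compound 1 to compound 4 (0.21 log units; that floor lies within the scatter).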

Compound 4, concentration lethal to 50% of the cells: > 32500 nM
Compound 4: a limit, no number (the forecaster's own chance of this, stated with the estimate: 50%); at least 1.6-fold (0.21 log units) between middle value and limit.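

Compound 1 and compound 4 each give only a limit in this assay, and the step between them cannot be read. The compounds shown leave open whether trifluoromethyl in place of chloro shifts the lethal concentration at all, and in which direction.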